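The source may hold more compounds than are shown below. What is called first, only, known or untested is meant among the compounds shown, and "the series" means these compounds.

Measured so far:
Compound 1 `CCN(Cc1ccncc1)c1cccc(C(=O)N2CCc3ccc(OS(N)(=O)=O)cc3C2)c1` — 52.8%
Compound 2 `CCN(Cc1cccc(Br)c1)c1cccc(C(=O)N2CCc3ccc(OS(N)(=O)=O)cc3C2)c1` — 24.9%

Among the compounds with values here, in an assay on HEK293 cells for inhibition of Steryl-sulfatase (Homo sapiens), tested at 1 uM (on this read-out lower numbers stand for a weaker effect and higher numbers for a stronger effect at the one concentration tested), compound 2 gives 24.9%, the lower of the two numbers so far. Its nearest neighbour is compound 1, which in this assay gives 52.8%. Within the data shown here, the one step recorded, a number 27.9 percentage points lower from compound 1 to compound 2 (beyond the scatter), is a modest drop beyond the scatter when 3-bromophenyl replaces pyridin-4-yl.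

Compound 3 `CCN(Cc1ccccn1)c1cccc(C(=O)N2CCc3ccc(OS(N)(=O)=O)cc3C2)c1` has not yet been measured in this assay. It differs from compound 2 as follows: pyridin-2-yl in place of 3-bromophenyl on a saturated chain carbon bound to a nitrogen on an aromatic ring. Among the measured compounds shown here, this change largely undoes the one recorded step, since the 3-bromophenyl group leaves and a pyridyl group returns, now attached at a different ring position. On that basis the step of a number 20.1 percentage points higher from compound 2 to compound 3 (beyond the scatter) is expected to run upward, of roughly the size seen in the recorded step. Compound 3 is therefore estimated at 45% in this assay, within a range of 25% to 65%.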

Compound 3, a percentage reported as inhibition, at one concentration (the size of the read-out at that concentration, not a potency): 19.9%
For compound 3 the middle estimate is 25.1 percentage points above the measured one, and the stated range ends above it.
By their numbers in this assay, from the lowest: compounds 3 and 2 (each within the scatter of the next); then compound 1.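

In this assay, the pyridin-2-yl group does not bring back the level seen with pyridin-4-yl. Exchanging it for 3-bromophenyl is a number 5 percentage points lower from compound 2 to compound 3 (within the scatter), so at this place, on a saturated chain carbon bound to a nitrogen on an aromatic ring, these two groups cannot be told apart. The change between the two pyridyl groups is a number 32.9 percentage points lower from compound 1 to compound 3 (beyond the scatter), which shows that among these three compounds a pyridine ring alone does not secure the higher number, and that pyridin-4-yl and pyridin-2-yl are not interchangeable here; nothing available accounts for this difference.

From the compounds shown here alone, it remains open whether a pyridin-3-yl group would fall with compound 1 or with compound 3. Also open, going by these compounds, is how an unsubstituted phenyl group would compare with 3-bromophenyl at this place.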